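Pyrazole Carboxamide to Acid: Cytotoxicity Outlook

The source may report more compounds than this note shows. Statements on the series, on what has been measured and on what is new or still open speak of the compounds shown alone.

Compound 1 `O=C(NCc1ccccc1)c1cn(-c2ccccc2)nc1-c1cccnc1` was run in a functional assay on MDA-MB-231 cells (Homo sapiens) for cytotoxicity, read by MTT assay, with a stated time of 48 h; on this read-out lower numbers stand for stronger inhibition and higher numbers for weaker inhibition. In this assay compound 1 reaches only the assay limit, > 100000 nM. Compound 2 `O=C(NCc1ccccc1)c1cn(-c2ccccc2)nc1-c1ccncc1` likewise returns only the limit > 100000 nM in this assay. The step that the two limits leave unreadable from compound 1 to compound 2 is thus unreadable, both values sitting at the limit of > 100000 nM in this assay, at which 2 of the 2 values shown sit. Compound 3 `O=C(O)c1cn(-c2ccccc2)nc1-c1ccncc1` differs from compound 2 by hydroxy in place of benzylamino on a carbonyl carbon. Among the compounds with values here, no measured step bears on this change, and the only anchor for compound 2 is a limit, so no readable step beyond the scatter is expected. Compound 3 is estimated at 150000 nM with a range of 50000 nM to 500000 nM. This estimate corresponds to an expected step that the limit leaves unreadable from compound 2 to compound 3.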

Compound 3, half-maximal inhibitory concentration: > 100000 nM
Compound 3 gave a limit, no number; the forecaster's own chance of this, stated with the estimate: 85%; the middle value lies beyond the limit too.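

No step can be read from compound 2 to compound 3 in this assay, both values being limits: the limit of > 100000 nM in this assay, at which 3 of the 3 values shown sit.

The compounds shown leave open whether hydroxy in place of benzylamino on a carbonyl carbon changes cytotoxicity at all, and what in this series would give a measurable value in this assay.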